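Swapping the Side-Chain Group in an Acid-Secretion Series

This account rests on a few compounds, and the source may have more. Where it says the series, first, only, none or still open, it means among the compounds named here.

The numbers come from a functional assay on the whole organism (stomach) with Rattus norvegicus as the target; a higher number here means that more compound is needed for the effect, a lower number that less compound is needed. Of the compounds shown here, three have been tested, and only one of them gives a number. Compound 2 `CC/N=C(/NC#N)NCCCCn1nc(-c2ccccc2)ccc1=O` reaches the half-maximal effect at 92 mg/kg. Compound 1 `C/N=C(/NC#N)NCCCCn1nc(C)ccc1=O` gives only a limit of the assay, > 100 mg/kg. Compound 3 `CN/C(=N/CCCCn1nc(-c2ccc(OC)cc2)ccc1=O)NC#N` likewise gives only a limit, > 100 mg/kg. So compound 2 stands alone with a number, while the limit of > 100 mg/kg in this assay, at which 2 of the 3 values shown sit, holds the other two values. No two of the three compounds differ in just one place, so no measured step can be read from them.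

Compound 4 `CC/N=C(\S)NCCCCn1nc(-c2ccccc2)ccc1=O` has not yet been tested in this assay. It differs from compound 2 in one group: a group of 5 heavy atoms (3 carbon, 1 nitrogen, 1 sulfur; no ring) in place of a group of 7 heavy atoms (4 carbon, 3 nitrogen; no ring), on an amine nitrogen. The shared core and the chain that carries it are unchanged.

Within the data shown here, since no measured step of this kind exists, the size of the change cannot be anchored to earlier data. The expected step is a 1.3-fold higher number from compound 2 to compound 4 (0.12 log units; within the scatter), a small shift that could fall either way. Compound 4 is therefore estimated at 120 mg/kg, with a likely range from 40 mg/kg to 400 mg/kg, and with a real chance that this assay again returns only a limit rather than a number.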

Compound 4, dose for half-maximal effect: 37.2 mg/kg
Compound 4: middle estimate off by 3.2-fold (0.51 log units), on the high side, outside the stated range (below it).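

In this assay, putting the group of 5 heavy atoms (3 carbon, 1 nitrogen, 1 sulfur; no ring) in place of the group of 7 heavy atoms (4 carbon, 3 nitrogen; no ring), on an amine nitrogen, gives a 2.5-fold lower number from compound 2 to compound 4 (0.39 log units; beyond the scatter). Among these compounds, this is the first step that can be read, and it shows that the group at this position can change the dose needed while the shared core and the chain stay the same, with the sulfur-bearing group needing less compound here. Compound 1 and compound 3 cannot add to this reading, as each differs from the others in more than one place and gives only a limit of the assay: the limit of > 100 mg/kg in this assay, at which 2 of the 4 values shown sit.

This single pair does not separate the effect of the sulfur entering from that of the triple bond leaving, so it cannot say which part of the swap accounts for the step. As far as these compounds go, how a group with oxygen in place of the sulfur, or a carboxylic acid, would behave at this place remains open, as does whether the same step would appear with the other ring substituents seen in compound 1 and compound 3.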